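The source may hold more compounds than are shown below. What is called first, only, known or untested is meant among the compounds shown, and "the series" means these compounds.

Measured compounds:
compound 1 `CCC(C)CNC(=O)c1ccc2c(c1)c(Cc1ccc(C(=O)NS(=O)(=O)c3ccccc3C)cc1OC)cn2C` — 1.39 umol/kg
compound 2 `COc1cc(C(=O)NS(=O)(=O)c2ccccc2C)ccc1Cc1cn(C)c2ccc(C(=O)NCC3CCCC3)cc12` — 0.69 umol/kg

Within the data shown here, in a functional assay (Cavia porcellus) for inhibition of cysteinyl leukotriene receptor (Homo sapiens) (a lower number here means that less compound is needed, a higher number that more compound is needed for the effect), compound 2 gives 0.69 umol/kg, the lower of the two numbers in hand, and its only neighbour is compound 1, where the sole measured step reads a 2.0-fold lower number from compound 1 to compound 2 (0.30 log units; within the scatter). Compound 3 `COc1cc(C(=O)NS(=O)(=O)c2ccccc2C)ccc1Cc1cn(C)c2ccc(C(=O)NCC(C)CC(F)(F)F)cc12` is not yet measured. It differs from compound 2 in one place: 3,3,3-trifluoro-1-methylpropyl in place of cyclopentyl on a saturated chain carbon bound to an amide-type nitrogen. Among the measured compounds shown here, the one step that bears on this change, a 2.0-fold lower number from compound 1 to compound 2 (0.30 log units; within the scatter), swapped a branched chain for the cyclopentyl ring and stayed within the scatter, so the move back to a branched chain in compound 3 gives no ground to expect a step beyond the scatter in this assay in either direction. For the measured compounds named here, the trifluoro end of the new chain has no measured counterpart here. Compound 3 is therefore expected to give about 1 umol/kg, with a range from 0.4 umol/kg to 2.5 umol/kg, a step of a 1.4-fold higher number from compound 2 to compound 3 (0.16 log units; within the scatter).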

Compound 3, dose for half-maximal effect: 0.036 umol/kg
Compound 3: the middle estimate sits 28-fold (1.44 log units) above what was measured; the measured number lies below the stated range.
By their numbers in this assay, from the lowest: compound 3; then compounds 2 and 1 (each within the scatter of the next).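

In this assay the chain on the amide-type nitrogen turns out to be able to shift the number well beyond the scatter, which the earlier step, lying within the scatter, gave no sign of: 4,4,4-trifluoro-2-methylbutyl in place of cyclopentylmethyl gives a 19-fold lower number from compound 2 to compound 3 (1.28 log units; beyond the scatter). Among these compounds, the comparison with the branched chain is the more telling one, since trifluoromethyl in place of methyl on a saturated chain carbon, three bonds along the chain from an amide-type nitrogen, is the only change in a 39-fold lower number from compound 1 to compound 3 (1.59 log units; beyond the scatter), so the large step here follows the fluorines and not the branching alone. The compounds shown offer no measurement that explains why the step is this large.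

Going by these compounds, whether difluoromethyl or monofluoromethyl in that place would keep the step remains open. So does the outcome with a longer chain ending in trifluoromethyl, or with an unbranched chain carrying the same group.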